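Sulfonylquinoxaline series: aniline swap on a methoxy-bearing core

The source may report more compounds than this note shows. Statements on the series, on what has been measured and on what is new or still open speak of the compounds shown alone.

Measured so far in a functional assay on PC-3 cells (Homo sapiens) for cytotoxicity, read by MTT assay, with a stated time of 72 h; a lower number here means a stronger inhibitor, a higher number a weaker inhibitor:
compound 1 `COc1cc(Nc2nc3ccccc3nc2S(=O)(=O)c2ccccc2)cc(OC)c1` gives 140 nM
compound 2 `Nc1ccc(Nc2nc3ccccc3nc2S(=O)(=O)c2ccccc2)cc1` gives 5830 nM
compound 3 `COc1ccc(S(=O)(=O)c2nc3ccccc3nc2Nc2cc(OC)cc(OC)c2)cc1` gives 6220 nM

Compound 1 is the reference point. One change from it, (4-aminophenyl in place of 3,5-dimethoxyphenyl on a nitrogen on an aromatic ring), is already measured: the step of a 42-fold higher number from compound 1 to compound 2 (1.62 log units; beyond the scatter) in this assay. A second change, (methoxy in place of hydrogen on an aromatic carbon), gives the step of a 44-fold higher number from compound 1 to compound 3 (1.65 log units; beyond the scatter). Compound 2 and compound 3 sit close together and their two values show no separation that could be read as an order.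

Compound 4 `COc1ccc(S(=O)(=O)c2nc3ccccc3nc2Nc2ccc(N)cc2)cc1` is not yet measured. It differs from compound 3 by 4-aminophenyl in place of 3,5-dimethoxyphenyl on a nitrogen on an aromatic ring, and the two cores differ by methoxy in place of hydrogen on an aromatic carbon. The place of the aniline swap is the same word for word in both pairs, so this is the same change, made on a core that carries the extra methoxy group.

If the aniline swap carried over unchanged from the step seen between compound 1 and compound 2, compound 4 would lie far weaker than compound 3. Going by the values given here, only one instance of the change is measured, and both compound 2 and compound 3 are already well weakened relative to compound 1, so a step of similar direction but less certain size is expected here: a 9.6-fold higher number from compound 3 to compound 4 (0.98 log units; beyond the scatter) in this assay. Compound 4 is therefore estimated at 60000 nM, with a range from 15000 nM to 300000 nM, and a fair chance that only a limit is reported.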

Compound 4, half-maximal inhibitory concentration: 9640 nM
The estimate for compound 4 lay 6.2-fold (0.79 log units) above the measured number; the whole stated range lies above it.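

The aniline swap on the methoxy-bearing core gives a 1.5-fold higher number from compound 3 to compound 4 (0.19 log units; within the scatter) in this assay and the methoxy change gives a 1.7-fold higher number from compound 2 to compound 4 (0.22 log units; within the scatter) on the core carrying 4-aminophenyl. The large step seen for the aniline swap on the core of compound 1 therefore does not carry over to the methoxy-bearing core: the same change on two cores in this assay, a 42-fold higher number (1.62 log units; beyond the scatter) from compound 1 to compound 2 and a 1.5-fold higher number (0.19 log units; within the scatter) from compound 3 to compound 4, 27-fold (1.43 log units) apart, beyond the scatter of two such steps. The methoxy change fails to carry over in the same way, but these four compounds form a single set, so the two gaps do not show which core is the exception, why the steps differ, or whether either step would hold on a further core: the same change on two cores in this assay, a 44-fold higher number (1.65 log units; beyond the scatter) from compound 1 to compound 3 and a 1.7-fold higher number (0.22 log units; within the scatter) from compound 2 to compound 4, 27-fold (1.43 log units) apart, beyond the scatter of two such steps.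

From the compounds shown here alone, it remains open whether 3,5-dimethoxyphenyl needs hydrogen rather than methoxy on the sulfonyl-bearing phenyl ring, or whether a chlorine or a methyl group in place of that methoxy would give a similar step. Also open, going by these compounds, is whether a hydroxyl or a carboxylic acid in place of the amine of 4-aminophenyl would fall with compound 2 and compound 4, and whether any of these steps would recur in other cell lines.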